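The source may report more compounds than this note shows. Statements on the series, on what has been measured and on what is new or still open speak of the compounds shown alone.

Compound 1 `CC(C)=CCCC1=CC[C@H](C(=O)Nc2ccc(O)cc2)[C@@H](c2ccccc2)C1` is the amide of the shared core with a (4-hydroxyphenyl)amino group, and in an assay on isolated protein for inhibition of Apoptosis regulator Bcl-2 (Homo sapiens), read by fluorescence polarization, with stated times of 5 min and 10 min (on this read-out higher numbers stand for weaker inhibition and lower numbers for stronger inhibition), compound 1 gives only a limit of the assay, > 23000 nM. Compound 2 `COC(=O)c1ccc(NC(=O)[C@@H]2CC=C(CCC=C(C)C)C[C@H]2c2ccccc2)cc1` carries a 4-(methoxycarbonyl)phenyl on the amide nitrogen, and in this assay compound 2 likewise gives only a limit, > 23000 nM. Compound 3 `CC(C)=CCCC1=CC[C@@H](C(=O)NO)[C@H](c2ccccc2)C1`, the free hydroxamic acid, gives in this assay 700 nM. Going by the values given here, the one step within this set, hydroxy in place of 4-(methoxycarbonyl)phenyl on an amide-type nitrogen, gives an at least 32-fold lower number from compound 2 to compound 3 (1.51 log units; beyond the scatter), and its size is bounded only by the limit of > 23000 nM in this assay, at which 2 of the 3 values shown sit.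

Compound 4 `CC(C)=CCCC1=CC[C@H](C(=O)N(C)O)[C@@H](c2ccccc2)C1` differs from compound 1 by hydroxy(methyl)amino in place of (4-hydroxyphenyl)amino on a carbonyl carbon. Among the compounds with values here, this change resembles the step from compound 2 to compound 3, in that an aryl amide gives way to a small hydroxylated nitrogen group on the carbonyl carbon, so a large step toward a lower number in this assay is expected, though no other compound with a hydroxy(methyl)amino group is present to fix its size. Compound 4 is therefore estimated at 1500 nM, between 400 nM and 8000 nM, which would mean an expected step of an at least 15-fold lower number from compound 1 to compound 4 (1.18 log units; beyond the scatter).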

Compound 4, inhibition constant: 2100 nM
Compound 4: middle estimate off by 1.4-fold (0.15 log units), on the low side, within the range that was stated.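

Hydroxy(methyl)amino in place of (4-hydroxyphenyl)amino on a carbonyl carbon gives, in this assay, an at least 10-fold lower number from compound 1 to compound 4 (1.03 log units; beyond the scatter), so a second aryl amide gives way to a measurable value once a small hydroxylated nitrogen group enters. In the earlier step that nitrogen kept its hydrogen, whereas here a methyl group stands on it and the value is still measurable, so the amide hydrogen is not required for a reading on this scale. The size of this new step has only a lower bound: the limit of > 23000 nM in this assay, at which 2 of the 4 values shown sit.

As far as these compounds go, whether a methylamino group or a carboxylic acid on that carbonyl carbon would give a comparable value stays open. What the methyl group contributes on its own also stays open, and no step in the compounds shown can isolate it.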